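From compound 3 to a tert-butyl analogue

A few compounds are considered here, and "the series" means these few. Any claim that something is new, unique, unknown or untested is made for them only; others in the source may bear on it.

Of the compounds shown here, three sharing one core have been measured in a functional assay on B16-F0 cells (Mus musculus) for inhibition, read by CCK-8 assay, with a stated time of 48 h; a lower number here means a stronger inhibitor, a higher number a weaker inhibitor. Compound 1 `COc1cc(-c2ccnc3cc(-c4cn(C)c5ccccc45)nn23)cc(OC)c1OC`, carrying 1-methyl-1H-indol-3-yl, gives 185 nM. Compound 2 `COc1ccc(-c2cc3nccc(-c4cc(OC)c(OC)c(OC)c4)n3n2)cc1`, carrying 4-methoxyphenyl, gives 1410 nM. Compound 3 `COc1ccc(-c2cc3nccc(-c4cc(OC)c(OC)c(OC)c4)n3n2)cc1F`, carrying 3-fluoro-4-methoxyphenyl, gives 3950 nM, the highest number of the three and so the weakest inhibition.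

Compound 4 `COc1cc(-c2ccnc3cc(-c4ccc(C(C)(C)C)cc4)nn23)cc(OC)c1OC` has 4-(tert-butyl)phenyl in place of 3-fluoro-4-methoxyphenyl on an aromatic carbon. Going by the values given here, no measured compound carries a tert-butyl group, so the estimate rests on neighbouring changes at this same place. Swapping the indole group for the two phenyl groups gave a 7.6-fold higher number from compound 1 to compound 2 (0.88 log units; beyond the scatter) and a 21-fold higher number from compound 1 to compound 3 (1.33 log units; beyond the scatter), a modest and a large step. The incoming group, like those in compound 2 and compound 3, has one six-membered aromatic ring of carbon only, so compound 4 is expected to sit nearer those two than compound 1. Adding fluoro in place of hydrogen gave a 2.8-fold higher number from compound 2 to compound 3 (0.45 log units; beyond the scatter), and the incoming group has no fluoro. In this assay the expected step is small, towards a lower number: a 1.8-fold lower number from compound 3 to compound 4 (0.25 log units; within the scatter). For compound 4 the estimated value is 2200 nM, with an expected range from 700 nM to 7000 nM.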

Compound 4, half-maximal inhibitory concentration: > 10000 nM
Compound 4: only a limit was reported; the forecaster's own chance of this, stated with the estimate: 5%; at least 4.5-fold (0.65 log units) between middle value and limit.
By their numbers in this assay, from the lowest: compound 1; then compound 2; then compound 3. At a limit, above all of these: compound 4.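

In this assay, compound 4 gives only a limit of the assay and not a number: the limit of > 10000 nM in this assay, at which 1 of the 4 values shown sits.

Even so, the steps show that this position responds strongly to what sits on the phenyl ring: tert-butyl in place of methoxy, the only change on that route, gives an at least 7.0-fold higher number from compound 2 to compound 4 (0.85 log units; beyond the scatter). The incoming group has no fluoro, yet the change still gives an at least 2.5-fold higher number from compound 3 to compound 4 (0.40 log units; beyond the scatter), and against the indole group it gives an at least 54-fold higher number from compound 1 to compound 4 (1.73 log units; beyond the scatter), so removing fluoro does not by itself bring inhibition back, and among these four compounds the 1-methyl-1H-indol-3-yl group remains the one with the lowest number.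

The compounds shown leave open whether a smaller alkyl group such as methyl or ethyl in place of tert-butyl would give a number closer to that of the methoxy compound, or whether an amine or a hydroxyl group on the phenyl ring would behave differently again. They also leave open how much of the advantage of the indole group depends on its methyl group, since an indole without that methyl is not among them.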